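From aminomethyl to 1-amino-1-methylethyl on a carbonyl

The source may hold more compounds than are shown below. What is called first, only, known or untested is meant among the compounds shown, and "the series" means these compounds.

Values in a functional assay on HCT-116 cells (Homo sapiens) for antiproliferative activity; on this read-out lower numbers stand for stronger inhibition and higher numbers for weaker inhibition:
- compound 1 `Cc1c2c(n3c1CCNC[C@@H](C)[C@H](C)Nc1cc-3ccc1C(N)=O)CC(C)(C)CC2=O` gives 24 nM
- compound 2 `Cc1c2c(n3c1CCN(C(=O)CN)C[C@@H](C)[C@H](C)Nc1cc-3ccc1C(N)=O)CC(C)(C)CC2=O` gives 216 nM
- compound 3 `Cc1c2c(n3c1CCCN(C(=O)CO)[C@@H](C)[C@H](C)Nc1cc-3ccc1C(N)=O)CC(C)(C)CC2=O` gives 51 nM

Compound 2 has the highest number of the three, so it is the weakest inhibitor here, and both other compounds lie beyond the scatter from it. Compound 4 `Cc1c2c(n3c1CCN(C(=O)C(C)(C)N)C[C@@H](C)[C@H](C)Nc1cc-3ccc1C(N)=O)CC(C)(C)CC2=O` is not yet measured. It differs from compound 2 by 1-amino-1-methylethyl in place of aminomethyl on a carbonyl carbon.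

Among the compounds with values here, one measured step bears on this change: a 9.0-fold higher number from compound 1 to compound 2 (0.95 log units; beyond the scatter). That modest step came with (aminomethyl)carbonyl in place of hydrogen on an amine nitrogen in a ring. It shows that the number can respond to a group at this nitrogen. Within the data shown here, no measured step alters the group on the carbonyl itself, so it offers only a loose guide. A small rise in this assay is therefore expected, probably within the scatter, as the estimate of a 1.3-fold higher number from compound 2 to compound 4 (0.11 log units; within the scatter) indicates. The expected value for compound 4 is 280 nM, with an estimated range of 90 nM to 850 nM.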

Compound 4, half-maximal inhibitory concentration: 25 nM
Estimate against measurement, compound 4: 11-fold (1.05 log units) above; measured number outside the range, below it.
By their numbers in this assay, from the lowest: compounds 1 and 4 (each within the scatter of the next); then compound 3; then compound 2.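

Swapping aminomethyl for 1-amino-1-methylethyl on the carbonyl carbon gives an 8.6-fold lower number from compound 2 to compound 4 (0.94 log units; beyond the scatter) in this assay, so the group on this carbonyl affects the number in its own right, and not only the presence of an acyl group on the ring nitrogen. The earlier step of a 9.0-fold higher number from compound 1 to compound 2 (0.95 log units; beyond the scatter) could have suggested that substitution on this nitrogen always raises the number, but a 1.0-fold higher number from compound 1 to compound 4 (0.02 log units; within the scatter) shows that compound 4 goes against this, with a substituent here and no change beyond the scatter. No measurement here explains why these two groups differ so much.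

As far as these compounds go, it remains open whether a 1-aminoethyl group, which lies between the two in size, or a ring such as 1-aminocyclopropyl would behave like compound 4. A 2-hydroxypropan-2-yl group, with a hydroxyl in place of the amine, would test whether that amine matters.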